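Dimethylamino in place of acetoxy: notes on compound 3

The compounds below may be only part of what the source reports. "The series", "measured", "known", "first", "only" and "open" are said of these compounds alone.

In a functional assay on NCI-H460 cells (Homo sapiens) (on this read-out higher numbers stand for an effect only at larger amounts of compound and lower numbers for an effect already at smaller amounts), compound 1 `COc1cc(C2OC(c3ccc(N(C)C)cc3)=NN2C=O)cc(OC)c1OC` gives 0.12 uM and compound 2 `COc1cc(C2OC(c3ccc(N(C)C)cc3)=NN2C(=O)COC(C)=O)cc(OC)c1OC` gives 0.072 uM. Among the compounds with values here, these are the only two numbers so far, and they lie within the scatter of each other. Compound 2 therefore holds no meaningful rank. Compound 3 `COc1cc(C2OC(c3ccc(N(C)C)cc3)=NN2C(=O)CN(C)C)cc(OC)c1OC` differs from compound 2 in one place: dimethylamino in place of acetoxy on a saturated chain carbon bound to a carbonyl carbon. Within the data shown here, only one measured step bears on this change: a 1.7-fold lower number from compound 1 to compound 2 (0.22 log units; within the scatter). That step stayed within the scatter, but it did not introduce dimethylamino, and it offers only weak guidance. No step beyond the scatter is expected in this assay, and no direction can be firmly expected. The expected change is a 1.4-fold higher number from compound 2 to compound 3 (0.14 log units; within the scatter). The estimate for compound 3 is 0.1 uM, with an expected range of 0.025 uM to 0.4 uM.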

Compound 3, concentration for half-maximal effect: 74 uM
The estimate for compound 3 lay 740-fold (2.87 log units) below the measured number, and the stated range ends below it.
By their numbers in this assay, from the lowest: compounds 2 and 1 (each within the scatter of the next); then compound 3.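

In this assay dimethylamino in place of acetoxy on a saturated chain carbon bound to a carbonyl carbon gives a 1000-fold higher number from compound 2 to compound 3 (3.01 log units; beyond the scatter) and so shows that this place responds strongly to the group it carries, which the earlier pair gave no sign of. Set against hydrogen on the carbonyl carbon, (dimethylamino)methyl gives a 620-fold higher number from compound 1 to compound 3 (2.79 log units; beyond the scatter) while acetoxymethyl stayed within the scatter of that hydrogen, so the outcome here depends on which group enters and not merely on a chain being present. No measurement at hand speaks to the origin of this loss.

On these data alone, whether hydroxy or methoxy on the same chain carbon would read like acetoxy or like dimethylamino remains open. So does the reading of a carboxylic acid there, or of a longer chain ending in dimethylamino.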